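Aryloxy extension at the methoxy position of compound 1

The source may report more compounds than this note shows. Statements on the series, on what has been measured and on what is new or still open speak of the compounds shown alone.

Measured so far:
compound 1 `COc1ccc(-c2ccn(CCC(C)C)c(=O)c2C#N)cc1` — 1150 nM in a functional assay on CHO cells for positive allosteric modulation of metabotropic glutamate receptor 2 (Homo sapiens), read by scintillation counting and GTPgammaS binding, with a stated time of 30 min; a higher number here means that more compound is needed for the effect, a lower number that less compound is needed
compound 2 `COc1ccc(-c2ccn(CCC(C)C)c(=O)c2C#N)cc1OC` — 260 nM in this assay

Compound 1 holds the higher of the two numbers in this assay; compound 2 lies a 4.4-fold lower number from compound 1 to compound 2 (0.65 log units; beyond the scatter), a methoxy in place of hydrogen on an aromatic carbon. Compound 3 `Cc1cc(Oc2ccc(-c3ccn(CCC(C)C)c(=O)c3C#N)cc2)ccn1` differs from compound 1 in another way: 2-methylpyridin-4-yl in place of methyl on an oxygen on an aromatic ring. Among the measured compounds shown here, no measured step addresses this exchange; the one measured step concerns a different position, so it gives only a rough sense of how much the number can move. Compound 3 is therefore expected near compound 1, with the estimate a 1.4-fold lower number from compound 1 to compound 3 (0.16 log units; within the scatter) and wide bounds: 800 nM, from 200 nM to 4000 nM.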

Compound 3, half-maximal effective concentration: 447 nM
Estimate against measurement, compound 3: 1.8-fold (0.25 log units) above, within the range that was stated.
By their numbers in this assay, from the lowest: compounds 2 and 3 (each within the scatter of the next); then compound 1.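

Methyl on the oxygen can give way to the far larger 2-methylpyridin-4-yl in this assay, with a 2.6-fold lower number from compound 1 to compound 3 (0.41 log units; beyond the scatter), so this position accepts an added six-membered aromatic ring without a rise in the number. Among the compounds shown here, the earlier step concerned a different change, so this is the first reading at the oxygen itself. No available evidence bears on the reason for this drop.

Open, as far as these compounds go, is whether phenyl or unmethylated pyridin-4-yl on the same oxygen would give a similar number. Also open, from the compounds shown here alone, is how the (2-methylpyridin-4-yl)oxy group would behave alongside the added methoxy of compound 2.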